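A few compounds are considered here, and "the series" means these few. Any claim that something is new, unique, unknown or untested is made for them only; others in the source may bear on it.

Measured so far in a functional assay on BJAB cells (Homo sapiens) for antiproliferative activity, with a stated time of 4 days; on this read-out lower numbers stand for an effect already at smaller amounts and higher numbers for an effect only at larger amounts of compound:

- compound 1 `Cc1nn(-c2nc(-c3ccc(Cl)c(Cl)c3)c(SC(C)C)s2)c(C(=O)O)c1-c1cnn(C)c1` gives 6800 nM
- compound 2 `Cc1nn(-c2nc(-c3ccc(Cl)c(Cl)c3)c(SC(C)C)s2)c(C(=O)O)c1-c1cc(C(F)(F)F)cc(C(F)(F)F)c1` gives 1800 nM
- compound 3 `CC(=O)Nc1ccc(-c2c(C)nn(-c3nc(-c4ccc(Cl)c(Cl)c4)c(SC(C)C)s3)c2C(=O)O)cc1` gives 139000 nM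

Compound 3 stands with the highest number of the three, so it needs the largest amount of compound for an effect; its nearest neighbour is compound 1, and compound 2 is furthest from it. Among the measured compounds shown here, the only change already measured at this position is the one from compound 1 to compound 3, where the 4-acetamidophenyl group replaced the methylpyrazolyl group and the number rose sharply, a 20-fold higher number from compound 1 to compound 3 (1.31 log units; beyond the scatter). Compound 4 `Cc1nn(-c2nc(-c3ccc(Cl)c(Cl)c3)c(SC(C)C)s2)c(C(=O)O)c1-c1cc(C#N)cc(C(F)(F)F)c1` differs from compound 3 in the same place: 3-cyano-5-(trifluoromethyl)phenyl in place of 4-acetamidophenyl on an aromatic carbon. The new group resembles the bis(trifluoromethyl)phenyl group of compound 2, which gives the lowest number among the measured compounds. A large downward step is therefore expected, a 46-fold lower number from compound 3 to compound 4 (1.67 log units; beyond the scatter), landing compound 4 close to compound 2. The estimate for compound 4 in this assay is 3000 nM, with a range from 800 nM to 12000 nM.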

Compound 4, half-maximal effective concentration: 3600 nM
Beside the measured number, compound 4's estimate is 1.2-fold (0.08 log units) below it, within the range that was stated.
By their numbers in this assay, from the lowest: compounds 2, 4 and 1 (each within the scatter of the next, the first and the last beyond it); then compound 3.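

Swapping the 4-acetamidophenyl group for 3-cyano-5-(trifluoromethyl)phenyl in this assay gives a 39-fold lower number from compound 3 to compound 4 (1.59 log units; beyond the scatter), so having a phenyl ring on this aromatic carbon does not by itself set compound 3 apart; what the ring carries matters. Cyano in place of one trifluoromethyl leaves a 2.0-fold higher number from compound 2 to compound 4 (0.30 log units; within the scatter), so this exchange makes no readable difference here. The phenyl group of compound 4 and the 1-methyl-1H-pyrazol-4-yl group of compound 1 also cannot be told apart, with a 1.9-fold lower number from compound 1 to compound 4 (0.28 log units; within the scatter), which leaves compound 3 alone in its high range among these four.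

Nothing shown explains why compound 3 stands so far from the others. As far as these compounds go, it also remains open whether a plain unsubstituted phenyl ring, or a phenyl ring carrying an amine or a carboxylic acid, would join compound 3 or the other three.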